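The source may hold more compounds than are shown below. What is called first, only, known or untested is meant among the compounds shown, and "the series" means these compounds.

Three compounds built on one shared core differ only in the aryl group attached to an aromatic nitrogen. Compound 1 `CC(=O)Nc1ccc(-n2nncc2CN2C(=O)C3(C(C#N)=C(N)Oc4c(N)cc5nc6ccccc6nc5c43)c3ccccc32)cc1` reaches only a limit in a functional assay on HepG2 cells (Homo sapiens) for antiproliferative activity, read by MTT assay, with a stated time of 48 h (a lower number here means a stronger inhibitor, a higher number a weaker inhibitor), giving > 50000 nM. Compound 2 `CCOc1ccccc1-n1nncc1CN1C(=O)C2(C(C#N)=C(N)Oc3c(N)cc4nc5ccccc5nc4c32)c2ccccc21` gives 30500 nM in this assay. Compound 3 `Cc1ccc(C)c(-n2nncc2CN2C(=O)C3(C(C#N)=C(N)Oc4c(N)cc5nc6ccccc6nc5c43)c3ccccc32)c1` also stops at a limit in this assay, at > 50000 nM. The measured steps are an at least 1.6-fold lower number from compound 1 to compound 2 (0.21 log units; that floor lies within the scatter) and an at least 1.6-fold higher number from compound 2 to compound 3 (0.21 log units; that floor lies within the scatter), while a step that the two limits leave unreadable from compound 1 to compound 3; two of the three values share (the limit of > 50000 nM in this assay, at which 2 of the 3 values shown sit). Compound 4 `N#CC1=C(N)Oc2c(N)cc3nc4ccccc4nc3c2C12C(=O)N(Cc1cnnn1-c1ccc(F)c(Cl)c1)c1ccccc12` differs from compound 3 by 3-chloro-4-fluorophenyl in place of 2,5-dimethylphenyl on an aromatic nitrogen. Since every aryl swap on this nitrogen so far changed the read-out little or unreadably, compound 4 is expected to stay weak, with an at least 1.1-fold lower number from compound 3 to compound 4 (0.04 log units; that floor lies within the scatter) as the expected step. The estimate for compound 4 is 45000 nM, ranging from 15000 nM to 120000 nM.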

Compound 4, half-maximal inhibitory concentration: > 50000 nM
Compound 4: only a limit was reported (the forecaster's own chance of this, stated with the estimate: 55%); middle value at least 1.1-fold (0.04 log units) from the limit.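

With 3-chloro-4-fluorophenyl, a ring carrying halogens rather than methyl groups, compound 4 also ends at a limit in this assay, so this change of ring substituents gives no visible gain: the limit of > 50000 nM in this assay, at which 3 of the 4 values shown sit.

The steps to compound 1 and compound 3 cannot be read: both ends are limits. Within the data shown here, the one readable step is an at least 1.6-fold higher number from compound 2 to compound 4 (0.21 log units; that floor lies within the scatter), so compound 2 is not clearly set apart from compound 4.

From the compounds shown here alone, how far compounds 1, 3 and 4 lie past the limit stays unknown, so they cannot be ranked. An amine or a carboxylic acid on this phenyl ring remains an open case.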